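The compounds below may be only part of what the source reports. "The series", "measured", "known", "first", "only" and "open" are said of these compounds alone.

In a functional assay on HL-60 cells (Homo sapiens) for inhibition, read by MTT assay, with a stated time of 48 h, tested at 10 uM (a higher number here means more inhibition of growth at the concentration tested, a lower number less inhibition of growth), compound 1 `Cc1cc(=O)c2c(O)c(CN3CCCC3)c(O)c([C@H]3CCN(C)C[C@H]3O)c2o1` gives 38% and compound 2 `Cc1cc(=O)c2c(O)c(CN3CCC(Cc4ccccc4)CC3)c(O)c([C@H]3CCN(C)C[C@H]3O)c2o1` gives 28% and these two numbers lie within the usual scatter of each other, so compound 1 stands level with compound 2. Compound 3 `Cc1cc(=O)c2c(O)c(CN3CC(O)CC3C(=O)O)c(O)c([C@H]3CCN(C)C[C@H]3O)c2o1` has not yet been measured. It carries 2-carboxy-4-hydroxypyrrolidin-1-yl in place of pyrrolidin-1-yl on a saturated chain carbon bound to an aromatic carbon. Among the compounds with values here, no measured pair shows what this exchange does, so the expectation is loose. In this assay a modest fall is expected (a number 13 percentage points lower from compound 1 to compound 3 (beyond the scatter)). Compound 3 is estimated at 25% within a range from 8% to 42% of growth inhibition.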

Compound 3, percent growth inhibition at one concentration: 28%
Compound 3: middle estimate off by 3 percentage points, on the low side, and the stated range covers the measured number.
By their numbers in this assay, from the lowest: compounds 2, 3 and 1 (each within the scatter of the next).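

In this assay, 2-carboxy-4-hydroxypyrrolidin-1-yl in place of pyrrolidin-1-yl on a saturated chain carbon bound to an aromatic carbon gives a number 10 percentage points lower from compound 1 to compound 3 (within the scatter). This position therefore accepts a ring with a carboxylic acid and a hydroxyl group, with no step beyond the scatter at the one concentration tested. Nothing available explains this result.

From the compounds shown here alone, what each added group does alone remains open, and a pyrrolidine ring bearing only the carboxylic acid or only the hydroxyl group would address this. Going by these compounds, how an open-chain amine such as dimethylamino would compare is also open.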